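Carboxyphenyl amide of a triazole carboxamide series

A few compounds are considered here, and "the series" means these few. Any claim that something is new, unique, unknown or untested is made for them only; others in the source may bear on it.

Compound 1 `COc1ccc(-n2nc(C(N)=O)nc2-c2cc(OC)c(OC)c(OC)c2)cc1`: 71%
Compound 2 `COc1ccc(-n2nc(C(=O)Nc3ccccc3OC)nc2-c2cc(OC)c(OC)c(OC)c2)cc1`: 24%
Compound 3 `COc1ccc(-n2nc(C(=O)Nc3cccc(F)c3)nc2-c2cc(OC)c(OC)c(OC)c2)cc1`: 70%

Of the compounds shown here, three have been measured in a functional assay on the whole organism for inhibition, with Rattus norvegicus as the target, read by paw edema, with stated times of 30 min and 4 h, at a dose of 0.28 mmol/kg by the oral route; a higher number here means more inhibition at the dose given (going by the name of the read-out), a lower number less inhibition. Compound 3 stands second highest of the three numbers; its nearest neighbour is compound 1, a number within the scatter of it, and the furthest is compound 2, far below it. Compound 4 `COc1ccc(-n2nc(C(=O)Nc3ccc(C(=O)O)cc3)nc2-c2cc(OC)c(OC)c(OC)c2)cc1` is not yet measured. It differs from compound 3 in one place: 4-carboxyphenyl in place of 3-fluorophenyl on an amide-type nitrogen.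

Going by the values given here, two measured steps bear on this change, since both alter the group on the amide-type nitrogen. The step of a number 1 percentage points lower from compound 1 to compound 3 (within the scatter) shows that a 3-fluorophenyl on that nitrogen leaves the number where hydrogen had it, whereas a number 47 percentage points lower from compound 1 to compound 2 (beyond the scatter) and a number 46 percentage points higher from compound 2 to compound 3 (beyond the scatter) show that a 2-methoxyphenyl there lowers it by a large amount. Nothing measured carries a carboxylic acid on the aryl group, so the direction for compound 4 is uncertain, and a moderate drop is taken as the middle course.

Compound 4 is therefore expected to give 55%, with a range of 25% to 80%, which means an expected step of a number 15 percentage points lower from compound 3 to compound 4 (beyond the scatter).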

Compound 4, a percentage reported as inhibition, in the whole organism at one dose (the size of the read-out at that dose, not a potency): 69%
Compound 4: the middle estimate sits 14 percentage points below what was measured; the measured number falls inside the stated range.
By their numbers in this assay, from the lowest: compound 2; then compounds 4, 3 and 1 (each within the scatter of the next).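

In this assay, the 4-carboxyphenyl group gives a number 1 percentage points lower from compound 3 to compound 4 (within the scatter) and a number 2 percentage points lower from compound 1 to compound 4 (within the scatter), so the amide-type nitrogen now carries hydrogen, 3-fluorophenyl or 4-carboxyphenyl with numbers that all lie within the scatter of one another. The 2-methoxyphenyl group of compound 2 is the one exception among these four compounds, with a number 45 percentage points higher from compound 2 to compound 4 (beyond the scatter), which shows that a large aryl-dependent loss at this position is not shared by every substituted phenyl group. Nothing available accounts for why these groups read alike or why compound 2 departs from them.

On these data alone, whether an unsubstituted phenyl on that nitrogen would read with compound 3 and compound 4 or with compound 2 stays open. So does the reading for a methyl ester or an amine in place of the carboxylic acid.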